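This account rests on a few compounds, and the source may have more. Where it says the series, first, only, none or still open, it means among the compounds named here.

Values measured in a physicochemical assay for solubility, in phosphate buffer, at pH 7.4 (a higher number here means a more soluble compound, a lower number a less soluble compound), are as follows.

- compound 1 `CC(C)n1cc(-c2ccnc3[nH]c(C4CCNCC4)cc23)ccc1=O` gives 910000 nM
- compound 2 `CC(=O)N1CCC(c2cc3c(-c4ccc(=O)n(C(C)C)c4)ccnc3[nH]2)CC1` gives 27000 nM
- compound 3 `CC(C)n1cc(-c2ccnc3[nH]c(C4CCN(Cc5cccs5)CC4)cc23)ccc1=O` gives 25000 nM

Compound 3 sits at the low end of these three values, far under compound 1 and level with compound 2. The gaps read a 36-fold lower number from compound 1 to compound 3 (1.56 log units; beyond the scatter) and a 1.1-fold lower number from compound 2 to compound 3 (0.03 log units; within the scatter) in this series.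

Next comes compound 4 `CC(C)n1cc(-c2ccnc3[nH]c(C4CCN(CC(=O)N(C)C)CC4)cc23)ccc1=O` with this difference from compound 3: dimethylcarbamoyl in place of thiophen-2-yl on a saturated chain carbon bound to an amine nitrogen in a ring and, cut one bond further out, the change reads (thiophen-2-yl)methyl to (dimethylcarbamoyl)methyl.

Both substituents measured on the amine nitrogen in a ring gave large steps, namely a 34-fold lower number from compound 1 to compound 2 (1.53 log units; beyond the scatter) and a 36-fold lower number from compound 1 to compound 3 (1.56 log units; beyond the scatter) in the values above. Among the measured compounds shown here, the closest precedent is the exchange of one such substituent for another, a 1.1-fold lower number from compound 2 to compound 3 (0.03 log units; within the scatter) as measured. For the measured compounds named here, no measured step swaps thiophen-2-yl on this chain carbon, so the evidence is indirect. The nitrogen stays substituted in compound 4, so no return to the level of compound 1 is expected. A modest upward lean is a judgement from the structural change alone. The expected move is a 2.4-fold higher number from compound 3 to compound 4 (0.38 log units; beyond the scatter) and it may prove smaller. For compound 4 the estimated value is 60000 nM with an expected range from 20000 nM to 250000 nM in this read-out.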

Compound 4, solubility: 110000 nM
For compound 4 the middle estimate is 1.8-fold (0.26 log units) below the measured one, within the range that was stated.
By their numbers in this assay, from the lowest: compounds 3 and 2 (each within the scatter of the next); then compound 4; then compound 1.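

In this assay the identity of the substituent on the amine nitrogen in a ring now counts, not only its presence: acetyl and (thiophen-2-yl)methyl stood level with a 1.1-fold lower number from compound 2 to compound 3 (0.03 log units; within the scatter) as their step, while (dimethylcarbamoyl)methyl separates from both, with a 4.4-fold higher number from compound 3 to compound 4 (0.64 log units; beyond the scatter) and with a 4.1-fold higher number from compound 2 to compound 4 (0.61 log units; beyond the scatter) as the steps. The exchange of thiophen-2-yl for dimethylcarbamoyl on the saturated chain carbon moves the number although the two groups match in heavy atoms and hydrogen-bond acceptors, yet the substituted nitrogen still stays short of the free one, with an 8.3-fold lower number from compound 1 to compound 4 (0.92 log units; beyond the scatter) as a modest step where a 34-fold lower number from compound 1 to compound 2 (1.53 log units; beyond the scatter) and a 36-fold lower number from compound 1 to compound 3 (1.56 log units; beyond the scatter) were large. No measurement at hand accounts for this step.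

Still open, going by these compounds, is whether a carboxylic acid or a tertiary amine in place of dimethylcarbamoyl, or a longer chain carrying the dimethylcarbamoyl, would bring the number closer to compound 1 at 910000 nM on this nitrogen. Also open, on these data alone, is whether the step follows the amide carbonyl or the departure of the thiophene ring, a question that a simple alkyl such as ethyl or a morpholine amide on the same chain carbon could help to separate.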